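The compounds below may be only part of what the source reports. "The series", "measured", "known", "first", "only" and "open" are said of these compounds alone.

Compound 1, whose structure is `O=C(/C=C\Nc1ccc(Cl)cc1)c1cn(-c2ccccc2)nc1-c1ccc(F)cc1`, is a useful starting point. In a functional assay on U-87MG ATCC cells (Homo sapiens) for antiproliferative activity, read by MTT assay, with a stated time of 48 h (on this read-out higher numbers stand for weaker inhibition and lower numbers for stronger inhibition), compound 1 gives 8900 nM. Compound 2, `COc1ccc(N/C=C\C(=O)c2cn(-c3ccccc3)nc2-c2ccc(F)cc2)cc1`, shares the same core and differs from compound 1 in one place only: methoxy in place of chloro on an aromatic carbon. That single change brings a 3.6-fold lower number from compound 1 to compound 2 (0.55 log units; beyond the scatter), so in this assay compound 2 gives 2500 nM.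

Compound 3, `O=C(/C=C\Nc1ccc(F)cc1)c1cn(-c2ccccc2)nc1-c1ccc(Cl)cc1`, is built from the same atoms as compound 1, joined differently; the difference between the two cores is not broken down here. In this assay compound 3 gives 17900 nM, a number that sits within the usual scatter of compound 1 but clearly apart from compound 2.

Compound 4, `COc1ccc(-c2nn(-c3ccccc3)cc2C(=O)/C=C\Nc2ccc(F)cc2)cc1`, is not yet measured. It differs from compound 3 by the same change already seen between compound 1 and compound 2: methoxy in place of chloro on an aromatic carbon. Because that change produced a 3.6-fold lower number from compound 1 to compound 2 (0.55 log units; beyond the scatter), a step of similar size and direction is expected here, while allowing that the change now sits one bond further out on a different phenyl. The expected step is a 3.0-fold lower number from compound 3 to compound 4 (0.47 log units; beyond the scatter), leading to an estimated 6000 nM for compound 4, between 2000 nM and 20000 nM.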

Compound 4, half-maximal inhibitory concentration: 8910 nM
Compound 4: the middle estimate sits 1.5-fold (0.17 log units) below what was measured; the measured number falls inside the stated range.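

The swap of chloro for methoxy brings a 2.0-fold lower number from compound 3 to compound 4 (0.30 log units; within the scatter) in this assay, so on this core the step taken alone cannot be told apart from the ordinary spread of repeated measurements. Among these compounds, with only two pairs, and one of those steps inside the scatter, this does not show that the change will give a real shift on every core, and it says nothing about why the change acts as it does. What it does show is that the two steps cannot be told apart, so nothing here suggests that the change behaves differently on the two cores: the same change on two cores in this assay, a 3.6-fold lower number (0.55 log units; beyond the scatter) from compound 1 to compound 2 and a 2.0-fold lower number (0.30 log units; within the scatter) from compound 3 to compound 4, 1.8-fold (0.25 log units) apart, within the scatter of two such steps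

The compounds shown leave open whether a group other than methoxy, such as an amine, a nitrile or a carboxylic acid, would behave in the same way in place of the chloro. They also leave open whether the swap would give a step of similar size on a third core.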